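The source may hold more compounds than are shown below. What is called first, only, known or untested is meant among the compounds shown, and "the series" means these compounds.

In a functional assay on A549 cells (Homo sapiens) for antiproliferative activity, read by sulforhodamine B assay, with a stated time of 3 days (a lower number here means that less compound is needed, a higher number that more compound is needed for the effect), compound 3 `CCCOC1=C(CCC)C(=O)/C(=C(O)/C=C/c2ccccc2)C(=O)C1(CCC)CCC` gives 1.9 uM. This lies within the scatter of compound 1 `CCCC1=C(OC)C(CCC)(CCC)C(=O)/C(=C(O)\C=C\c2ccc(I)cc2)C1=O` at 1.4 uM, and clearly under compound 2 `CCCC1=C(OCCC(C)C)C(CCC)(CCC)C(=O)/C(=C(O)\C=C\c2ccccc2)C1=O` at 11.3 uM. Compound 4 `CCCOC1=C(CCC)C(=O)/C(=C(O)/C=C/c2ccc(I)cc2)C(=O)C1(CCC)CCC` keeps everything in compound 3 except that phenyl becomes 4-iodophenyl: iodo in place of hydrogen on an aromatic carbon. Within the data shown here, the only measured step, a 5.9-fold lower number from compound 2 to compound 3 (0.77 log units; beyond the scatter), concerns the chain on oxygen, so it does not bear directly on this change. Among the measured compounds shown here, no measured pair isolates the iodo group. Compound 1 carries the same 4-iodophenyl with a methoxy group and gives 1.4 uM, so no shift beyond the scatter is expected in this assay. The expected step is a 1.3-fold lower number from compound 3 to compound 4 (0.10 log units; within the scatter). Compound 4 is estimated at 1.5 uM, with an expected range of 0.5 uM to 4.5 uM.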

Compound 4, concentration for half-maximal effect: 8.2 uM
For compound 4 the middle estimate is 5.5-fold (0.74 log units) below the measured one; measured number outside the range, above it.
By their numbers in this assay, from the lowest: compounds 1 and 3 (each within the scatter of the next); then compounds 4 and 2 (each within the scatter of the next).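

In this assay, among these compounds, iodo in place of hydrogen on an aromatic carbon, para to a large group, gives a 4.3-fold higher number from compound 3 to compound 4 (0.64 log units; beyond the scatter), the first direct reading of this change, and it makes the number higher. With 4-iodophenyl held fixed, ethyl in place of hydrogen on the saturated chain carbon bound to oxygen gives a 5.9-fold higher number from compound 1 to compound 4 (0.77 log units; beyond the scatter), so the chain on oxygen also counts in this series. No measurement shown accounts for either step. The compounds shown leave open whether fluoro or chloro at this place would shift the number as iodo does. They also leave open whether iodo has the same effect when the chain on oxygen is shorter.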